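A few compounds are considered here, and "the series" means these few. Any claim that something is new, unique, unknown or untested is made for them only; others in the source may bear on it.

Three compounds share one core and differ only in the groups on their two outer aromatic rings. Compound 1 `Cc1ccc(N2CC(c3nc(-c4cccc(C)c4)no3)CC2=O)cc1` gives 1300 nM in an in vitro functional assay on HEK293-A cells for positive allosteric modulation of metabotropic glutamate receptor 5 (Homo sapiens), read by FLIPR and calcium flux; a higher number here means that more compound is needed for the effect, a lower number that less compound is needed. Compound 2 `Cc1ccc(N2CC(c3nc(-c4cccc(F)c4)no3)CC2=O)cc1` gives 1200 nM in this assay. Compound 3 `O=C1CC(c2nc(-c3cccc(F)c3)no2)CN1c1ccc(Cl)cc1` gives 630 nM in this assay.

Compound 2 and compound 1 differ by one change, (methyl in place of fluoro on an aromatic carbon). This change gave a 1.1-fold higher number from compound 2 to compound 1 (0.03 log units; within the scatter). Compound 2 and compound 3 differ by another single change, (chloro in place of methyl on an aromatic carbon). That step was a 1.9-fold lower number from compound 2 to compound 3 (0.28 log units; within the scatter).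

Compound 4 `Cc1cccc(-c2noc(C3CC(=O)N(c4ccc(Cl)cc4)C3)n2)c1` has not yet been measured in this assay. It differs from compound 3 by methyl in place of fluoro on an aromatic carbon. For the measured compounds named here, this is the same change as the one from compound 2 to compound 1: in both cases the group sits on an aromatic carbon of a six-membered aromatic ring of carbon only, meta to a large group. The cores on which the change is made differ in the way described by chloro in place of methyl on an aromatic carbon.

Since the same change made from compound 2 to compound 1 only produced a 1.1-fold higher number from compound 2 to compound 1 (0.03 log units; within the scatter), the step from compound 3 to compound 4 is expected to be similar, a 1.1-fold higher number from compound 3 to compound 4 (0.05 log units; within the scatter). On that basis compound 4 is estimated to give 700 nM in this assay, with a likely range from 350 nM to 1400 nM.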

Compound 4, half-maximal effective concentration: 170 nM
Compound 4: middle estimate off by 4.1-fold (0.61 log units), on the high side, and the stated range ends above it.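

In this assay, the change from 3-fluorophenyl to 3-methylphenyl gave a 3.7-fold lower number from compound 3 to compound 4 (0.57 log units; beyond the scatter), so the result of the same change on the core of compound 2 did not carry over to the core of compound 3: the same change on two cores in this assay, a 1.1-fold higher number (0.03 log units; within the scatter) from compound 2 to compound 1 and a 3.7-fold lower number (0.57 log units; beyond the scatter) from compound 3 to compound 4, 4.0-fold (0.60 log units) apart, beyond the scatter of two such steps. Read from the other ring, chloro in place of methyl gave a 7.6-fold lower number from compound 1 to compound 4 (0.88 log units; beyond the scatter), which also stands apart from the same change made with fluoro on the other ring: the same change on two cores in this assay, a 1.9-fold lower number (0.28 log units; within the scatter) from compound 2 to compound 3 and a 7.6-fold lower number (0.88 log units; beyond the scatter) from compound 1 to compound 4, 4.0-fold (0.60 log units) apart, beyond the scatter of two such steps. Both comparisons rest on the same four compounds and are two views of one observation, so they show that the effect of a change on one ring depended here on the group on the other ring, but they do not show why, or whether this holds beyond these compounds.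

The compounds shown leave open whether the low number of compound 4 is specific to the pairing of chloro and methyl, or whether it would also appear with bromo in place of chloro, or with ethyl or methoxy in place of methyl. They also leave open whether the same dependence between the two rings would appear on a core other than the shared one.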